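Biaryl sulfonamide series: cytotoxicity notes on compound 3

The source may report more compounds than this note shows. Statements on the series, on what has been measured and on what is new or still open speak of the compounds shown alone.

Two compounds of this series carry a reading in a functional assay on J774 cells (Mus musculus) for cytotoxicity, read by resazurin assay, with a stated time of 72 h; on this read-out higher numbers stand for weaker inhibition and lower numbers for stronger inhibition. Compound 1 `O=C(Nc1cccc(CO)c1)c1ccc(-c2ccc(F)cc2F)cc1` sits at the edge of the assay: in this assay compound 1 gives > 15000 nM, and this is a limit of the assay rather than a number (the limit of > 15000 nM in this assay, at which 1 of the 2 values shown sits). Going by the values given here, compound 2 `O=S(=O)(Nc1cccc(CO)c1)c1ccc(-c2ccc(C(F)(F)F)cc2)cc1` is the only compound with a numeric value so far; in this assay compound 2 gives 2500 nM. Among the compounds with values here, compound 1 and compound 2 differ in more than one place, so no single step between them is set out, and their two values stand on their own.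

Compound 3 `CC(=O)Nc1ccc(-c2ccc(S(=O)(=O)Nc3cccc(CO)c3)cc2)cc1` is not yet measured. It differs from compound 2 by acetamido in place of trifluoromethyl on an aromatic carbon. Within the data shown here, no measured step covers a change of this kind, so the expectation rests on compound 2 at 2500 nM alone. In this assay the expected step is estimated as a 2.4-fold higher number from compound 2 to compound 3 (0.38 log units; beyond the scatter), in the direction of weaker inhibition, with a real chance of a limit reading. For compound 3 the estimate in this assay is 6000 nM, with a range from 2000 nM to 15000 nM.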

Compound 3, half-maximal inhibitory concentration: > 5000 nM
Compound 3: a limit, no number; the forecaster's own chance of this, stated with the estimate: 35%; the middle value does not contradict the limit.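

In this assay compound 3 reads only as a limit of the assay, not as a number: the limit of > 5000 nM in this assay, at which 1 of the 3 values shown sits. Acetamido in place of trifluoromethyl, on an aromatic carbon para to a large group, gives an at least 2.0-fold higher number from compound 2 to compound 3 (0.30 log units; that floor lies within the scatter) as the first step that can be read at this position. This is a floor and not a measured size, so it does not establish a change beyond the scatter, but the reading gives no sign of stronger inhibition with acetamido here than with trifluoromethyl.

Going by these compounds alone, how far compound 3 lies past its limit stays open, and with it the true size of the step, so the series still holds only one numeric value in this assay. Also open, from the compounds shown here alone, is how a primary amine or a carboxylic acid on this aromatic carbon would read against the trifluoromethyl of compound 2, and whether any such group would give a number rather than a limit.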